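Adding One Carbon to the Bromoalkyl Chain

This account rests on a few compounds, and the source may have more. Where it says the series, first, only, none or still open, it means among the compounds named here.

In a functional assay on A549 cells (Homo sapiens) for antiproliferative activity, read by MTT assay, with a stated time of 48 h (on this read-out higher numbers stand for weaker inhibition and lower numbers for stronger inhibition), compound 1 `COc1ccc(N(C)c2ccnc(Cl)n2)cc1F` gives 651 nM, compound 2 `COc1ccc(N(C)c2ccnc(Cl)n2)cc1[N+](=O)[O-]` gives 3780 nM and compound 3 `COc1ccc(N(C)c2ccnc(Cl)n2)cc1OCCCCBr` gives 591 nM. Compound 3 stands level with the fluoro compound and clear of the nitro compound: 4-bromobutoxy in place of fluoro gave a 1.1-fold lower number from compound 1 to compound 3 (0.04 log units; within the scatter), and in place of nitro it gave a 6.4-fold lower number from compound 2 to compound 3 (0.81 log units; beyond the scatter). Compound 4 `COc1ccc(N(C)c2ccnc(Cl)n2)cc1OCCCCCBr` carries one change: bromomethyl in place of bromo on a saturated chain carbon, four bonds along the chain from an oxygen on an aromatic ring. Going by the values given here, no measured step alters the chain length, and these two steps bear on it only indirectly. No change beyond the scatter is therefore expected in this assay, and the estimated step is a 1.0-fold higher number from compound 3 to compound 4 (0.01 log units; within the scatter). The expected value for compound 4 is 600 nM, within an estimated range of 260 nM to 1400 nM.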

Compound 4, half-maximal inhibitory concentration: 9720 nM
The estimate for compound 4 lay 16-fold (1.21 log units) below the measured number, outside the stated range (above it).
By their numbers in this assay, from the lowest: compounds 3 and 1 (each within the scatter of the next); then compound 2; then compound 4.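

In this assay, this position proved sensitive to a single added carbon: bromomethyl in place of bromo, four bonds along the chain from an oxygen on an aromatic ring, gave a 16-fold higher number from compound 3 to compound 4 (1.22 log units; beyond the scatter). The level standing of the 4-bromobutoxy compound with the fluoro compound did not carry over to the (5-bromopentyl)oxy compound, which gave a 15-fold higher number from compound 1 to compound 4 (1.17 log units; beyond the scatter) and a 2.6-fold higher number from compound 2 to compound 4 (0.41 log units; beyond the scatter).

On these data alone, whether a 3-bromopropyl chain, a longer chain or an amine in place of bromo would read like compound 3 or compound 4 remains open. Nothing available explains the size of this step.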